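Cyclopropylamino to pyrrolidin-1-yl at the clearance limit

A few compounds are considered here, and "the series" means these few. Any claim that something is new, unique, unknown or untested is made for them only; others in the source may bear on it.

Measured so far in an ADME assay on microsomes from liver (Mus musculus) for metabolic stability, read by LC-MS, with a stated time of 40 min, tested at 0.5 uM; on this read-out lower numbers stand for slow clearance and higher numbers for fast clearance (both values are limits):
- compound 1 `O=C(Nc1cccc(S(=O)(=O)C2CCCC2)c1)c1cccnc1N1CCC(F)(F)CC1` gives > 399 mL.min-1.g-1
- compound 2 `O=C(Nc1cccc(S(=O)(=O)NC2CC2)c1)c1cccnc1N1CCC2(CC1)CC2` gives > 399 mL.min-1.g-1

Compound 2 reads > 399 mL.min-1.g-1 as a limit of the assay and not as a number. Among the measured compounds shown here, the series so far shows the limit of > 399 mL.min-1.g-1 in this assay, at which 2 of the 2 values shown sit, and no measured pair gives a step.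

Compound 3 `O=C(Nc1cccc(S(=O)(=O)N2CCCC2)c1)c1cccnc1N1CCC2(CC1)CC2` carries pyrrolidin-1-yl in place of cyclopropylamino on a sulfonyl sulfur and otherwise matches compound 2.

No measured change of this kind exists to size the step. The expectation rests on compound 2 at > 399 mL.min-1.g-1 alone, a limit and not a number. Clearance in this assay is expected to stay fast, with no step beyond the scatter in either direction. The estimated move is an at least 1.1-fold lower number from compound 2 to compound 3 (0.05 log units; that floor lies within the scatter) and it is expected to lie within the scatter. For compound 3 the expected intrinsic clearance is 350 mL.min-1.g-1 with an estimated range from 170 mL.min-1.g-1 to 600 mL.min-1.g-1. An outcome that is only a limit would be no surprise.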

Compound 3, intrinsic clearance in microsomes: > 399 mL.min-1.g-1
Compound 3 was reported as a limit; the forecaster's own chance of this, stated with the estimate: 55%; at least 1.1-fold (0.05 log units) between middle value and limit.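

In this assay compound 3 gives > 399 mL.min-1.g-1, a limit of the assay and not a number. Compound 2 is also reported as a limit, so no step can be read between compound 2 and compound 3. The series now shows: the limit of > 399 mL.min-1.g-1 in this assay, at which 3 of the 3 values shown sit.

The compounds shown leave open how their actual clearances compare and which structures would give a value inside the limit.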